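A few compounds are considered here, and "the series" means these few. Any claim that something is new, unique, unknown or untested is made for them only; others in the source may bear on it.

Of the compounds shown here, two that share one core have been measured so far in a functional assay on MCF7 cells (Homo sapiens) for inhibition, read by MTT assay, with a stated time of 48 h, tested at 10 uM; a higher number here means more inhibition of growth at the concentration tested, a lower number less inhibition of growth. Compound 1 (`Cc1oc2c([C@H]3CCN(C)C[C@H]3O)c(O)cc(O)c2c(=O)c1C(O)c1cccc(Cl)c1`), with a 3-chlorophenyl group, gives 5%. Compound 2 (`Cc1oc2c([C@H]3CCN(C)C[C@H]3O)c(O)cc(O)c2c(=O)c1C(O)c1cc(F)cc(F)c1`), with a 3,5-difluorophenyl group at the same place, gives 25%, the higher of the two numbers.

Compound 3 (`Cc1oc2c([C@H]3CCN(C)C[C@H]3O)c(O)cc(O)c2c(=O)c1C(O)c1cccc(Cl)c1Cl`) has not yet been measured. It has 2,3-dichlorophenyl in place of 3,5-difluorophenyl on a saturated chain carbon bound to an aromatic carbon and an oxygen on a saturated carbon.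

Among the measured compounds shown here, only one measured step bears on this change, the exchange of groups at that same place, which gave a number 20 percentage points higher from compound 1 to compound 2 (beyond the scatter). For the measured compounds named here, this modest step is thin support, and no measured compound carries the 2,3-dichlorophenyl group. Still, the ring of compound 3 bears chlorine, as does the ring of compound 1, which gives 5%. A modest fall back toward that lower number is therefore the best guess. The expected change is a number 13 percentage points lower from compound 2 to compound 3 (beyond the scatter). The estimate for compound 3 is 12%, with an expected range of 0% to 30%.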

Compound 3, percent growth inhibition at one concentration: 7%
The estimate for compound 3 lay 5 percentage points above the measured number; the range from low to high includes it.
By their numbers in this assay, from the lowest: compounds 1 and 3 (each within the scatter of the next); then compound 2.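

In this assay, replacing the 3,5-difluorophenyl group with 2,3-dichlorophenyl gives a number 18 percentage points lower from compound 2 to compound 3 (beyond the scatter) at the same place on the saturated chain carbon, so the earlier rise does not carry over to this second dihalogenated ring. The step that adds one chloro in place of hydrogen on an aromatic carbon gives a number 2 percentage points higher from compound 1 to compound 3 (within the scatter) and so leaves the two chlorine-bearing compounds indistinguishable here, even though their rings carry different numbers of chlorines. Among these three compounds, then, the two with chlorine on the ring sit together, and compound 2, the only one with fluorine, stands clear of both, with no compound shown going against that split.

On these data alone, compound 2 and compound 3 differ both in the halogen and in where it sits on the ring, so these compounds cannot show which of the two matters, and how a ring carrying a methoxy group or an amine would behave also stays open. Nothing measured here gives a reason for the gap between the fluorine-bearing ring and the chlorine-bearing rings.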